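The compounds below may be only part of what the source reports. "The series", "measured", "known", "first", "only" and "open" are said of these compounds alone.

Compound 1 `CCOC(=O)C1(Cc2ccccc2)CN(c2ccccc2)Cc2nnn(Cc3cccc(F)c3)c21`: in an ADME assay on HEL cells (Homo sapiens) for cytotoxicity, read by microscopy, with a stated time of 3 days (a higher number here means that more compound is tolerated, a lower number that less compound is tolerated), compound 1 gives >= 100000 nM, a limit of the assay.
Compound 2 `CCOC(=O)C1(Cc2ccccc2)CN(c2ccccc2)Cc2nnn(Cc3ccc(Cl)cc3)c21`: in this assay compound 2 gives > 100000 nM, also a limit of the assay.
Compound 3 `CCOC(=O)C1(Cc2ccccc2)CN(c2ccccc2)Cc2nnn(Cc3ccco3)c21`: in this assay compound 3 gives 100000 nM.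

Going by the values given here, compound 3 holds the only plain number in this assay; the two other values are limits. Compound 4 `CCCCCCCCn1nnc2c1C(Cc1ccccc1)(C(=O)OCC)CN(c1ccccc1)C2` differs from it by heptyl in place of furan-2-yl on a saturated chain carbon bound to an aromatic nitrogen. The measured steps all swap the group on a saturated chain carbon bound to an aromatic nitrogen: a step that the two limits leave unreadable from compound 1 to compound 2, a number no higher from compound 1 to compound 3 (the limit leaves the size open) and a number no higher from compound 2 to compound 3 (the limit leaves the size open). None of them has a readable size, so no movement beyond the scatter is expected in this assay, and the expected step is no change at the digits printed from compound 3 to compound 4 (within the scatter). Compound 4 is therefore estimated to give 100000 nM, between 30000 nM and 100000 nM.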

Compound 4, minimum cytotoxic concentration: >= 20000 nM
Compound 4: a limit, no number; the forecaster's own chance of this, stated with the estimate: 60%; the middle value is on the limit's open side.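

The value of compound 4 is a limit and not a number, so no step linking it to compound 1, compound 2 or compound 3 can be read: the limit of >= 20000 nM in this assay, at which 1 of the 4 values shown sits.

The compounds shown leave open whether heptyl in place of furan-2-yl changes the concentration tolerated in this assay.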